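The compounds below may be only part of what the source reports. "The series", "measured", "known", "first", "only" and "open" are said of these compounds alone.

Compound 3 `COc1ccc(-c2cc(/C=C/C(=O)c3ccc(N)cc3)[nH]n2)cc1OC` stands at the top of the three numbers measured in a functional assay on MDA-MB-435 cells (Homo sapiens) for inhibition, read by sulforhodamine B assay, with a stated time of 48 h (a lower number here means that less compound is tolerated, a higher number that more compound is tolerated), where compound 3 gives 40800 nM. The nearest of the others is compound 2 `COc1ccc(-c2cc(/C=C/C(=O)c3ccc(OC)c(OC)c3)[nH]n2)cc1`, which in this assay gives 8170 nM, and the furthest is compound 1 `COc1cc(-c2cc(/C=C/C(=O)c3ccc(N)cc3)[nH]n2)cc(OC)c1OC`, which in this assay gives 6200 nM.

Compound 4 `COc1ccc(-c2cc(/C=C/C(=O)c3ccc(N)cc3)[nH]n2)cc1` is not yet measured. It differs from compound 3 as follows: hydrogen in place of methoxy on an aromatic carbon.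

For the measured compounds named here, one measured step bears on this change. Going a 6.6-fold higher number from compound 1 to compound 3 (0.82 log units; beyond the scatter) shows the same kind of replacement on the same ring raising the number in this assay by a modest amount. Going by the values given here, with only that single step to go on, the expectation is that compound 4 will again sit higher than compound 3, with a step of similar or somewhat smaller size, that is a 2.2-fold higher number from compound 3 to compound 4 (0.34 log units; beyond the scatter), expected in this assay. Compound 4 is therefore estimated in this assay at 90000 nM, with a range from 35000 nM to 230000 nM.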

Compound 4, concentration lethal to 50% of the cells: 38200 nM
Compound 4: middle estimate off by 2.4-fold (0.37 log units), on the high side; low and high end bracket the measured number.
By their numbers in this assay, from the lowest: compounds 1 and 2 (each within the scatter of the next); then compounds 4 and 3 (each within the scatter of the next).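

In this assay, replacing methoxy with hydrogen on this ring, at the place ortho to a methoxy group and meta to a large group, gives a 1.1-fold lower number from compound 3 to compound 4 (0.03 log units; within the scatter) and so leaves the number within the scatter. The same kind of replacement gave a 6.6-fold higher number from compound 1 to compound 3 (0.82 log units; beyond the scatter) and so moved the number beyond the scatter, which shows that this change does not carry one constant step on this ring. Nothing shown here accounts for the difference between these two steps.

A fluorine atom, a hydroxy group or an amine at this place does not occur among the compounds shown, so it stays open whether only the loss of methoxy is without consequence here. Also open, as far as these compounds go, is what a ring bearing no methoxy at all would give.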